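Exchanging the Halophenyl Ring on the Cinnamamide Chain

The compounds below may be only part of what the source reports. "The series", "measured", "known", "first", "only" and "open" are said of these compounds alone.

Measured so far:
compound 1 `O=C(/C=C/c1ccco1)Nc1ccc2c(c1)COC2=O` gives 9000 nM
compound 2 `O=C(/C=C/c1cccc(F)c1)Nc1ccc2c(c1)COC2=O` gives 34 nM

In a functional assay on cells (T-cell, Mus musculus) for inhibition (on this read-out lower numbers stand for stronger inhibition and higher numbers for weaker inhibition), compound 2 stands lowest of the two numbers. Among the measured compounds shown here, the only measured step is a 260-fold lower number from compound 1 to compound 2 (2.42 log units; beyond the scatter), a large one. Compound 3 `O=C(/C=C/c1ccccc1Br)Nc1ccc2c(c1)COC2=O` differs from compound 2 by 2-bromophenyl in place of 3-fluorophenyl on a double-bonded chain carbon bound to a double-bonded chain carbon. That step bears only loosely here, since it exchanged a furan for a phenyl ring rather than one halophenyl for another. For the measured compounds named here, no measured step shows such a swap, so compound 3 is expected to give 80 nM, within 20 nM to 400 nM, a step of a 2.4-fold higher number from compound 2 to compound 3 (0.37 log units; beyond the scatter) expected to stay near the scatter.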

Compound 3, half-maximal inhibitory concentration: > 100000 nM
Compound 3: a limit, no number (the forecaster's own chance of this, stated with the estimate: 5%); middle value at least 1200-fold (3.09 log units) away from the limit.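

In this assay compound 3 gives > 100000 nM, which is a limit of the assay and not a number. This place on the chain therefore does not accept every halophenyl ring, as 2-bromophenyl in place of 3-fluorophenyl gives an at least 2900-fold higher number from compound 2 to compound 3 (3.46 log units; beyond the scatter). A phenyl ring alone does not carry the earlier gain either, since 2-bromophenyl in place of furan-2-yl gives an at least 11-fold higher number from compound 1 to compound 3 (1.04 log units; beyond the scatter).

The compounds shown leave open whether the halogen or where it sits on the ring decides this result. They also leave open how 3-bromophenyl or 2-fluorophenyl would read at this place.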